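The source may hold more compounds than are shown below. What is called first, only, known or untested is meant among the compounds shown, and "the series" means these compounds.

Measured in a functional assay on CHO cells with adenosine receptor A1 (Homo sapiens) as the target, read by cAMP accumulation and immunoassay, with a stated time of 6 min, tested at 10 uM; on this read-out lower numbers stand for a stronger effect and higher numbers for a weaker effect at the one concentration tested:
compound 1 `Nc1scc(CN2CCN(c3ccc(Cl)cc3Cl)CC2)c1C(=O)c1ccc(Cl)cc1` — -74%
compound 2 `Nc1scc(CN2CCN(c3cccnc3)CC2)c1C(=O)c1ccc(Cl)cc1` — -23%
compound 3 `Nc1scc(CN2CCN(C3CCCCCC3)CC2)c1C(=O)c1ccc(Cl)cc1` — -25%

Compound 3 holds the second highest of the three numbers. Its nearest neighbour is compound 2, the gap a number 2 percentage points lower from compound 2 to compound 3 (within the scatter) lying within the scatter, so the two cannot be ordered. Compound 1 is furthest off, the step of a number 49 percentage points higher from compound 1 to compound 3 (beyond the scatter) being large and beyond the scatter.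

Compound 4 `Nc1scc(CN2CCN(c3ccc(F)c(F)c3)CC2)c1C(=O)c1ccc(Cl)cc1` is the next compound for this assay. Its change from compound 3 is 3,4-difluorophenyl in place of cycloheptyl on an amine nitrogen in a ring.

Within the data shown here, two measured steps bear on it. The step of a number 49 percentage points higher from compound 1 to compound 3 (beyond the scatter) shows that replacing 2,4-dichlorophenyl by cycloheptyl moves the number far upward; compound 4 reverses the sense of that change by bringing a halogenated phenyl back onto the ring nitrogen, though 3,4-difluorophenyl rather than 2,4-dichlorophenyl. The step of a number 51 percentage points higher from compound 1 to compound 2 (beyond the scatter) shows that an aromatic ring as such, pyridin-3-yl, does not hold the low number of compound 1, so the return toward compound 1 is expected to be partial. A large downward step a number 25 percentage points lower from compound 3 to compound 4 (beyond the scatter) is therefore expected. Compound 4 is estimated at -50%, with a range from -78% to -22%.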

Compound 4, a percentage reported as activity, at one concentration (the size of the read-out at that concentration, not a potency): -87%
The estimate for compound 4 lay 37 percentage points above the measured number, and the stated range ends above it.
By their numbers in this assay, from the lowest: compound 4; then compound 1; then compounds 3 and 2 (each within the scatter of the next).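

On the amine nitrogen in a ring, in this assay, 3,4-difluorophenyl gives a number 62 percentage points lower from compound 3 to compound 4 (beyond the scatter) and a number 64 percentage points lower from compound 2 to compound 4 (beyond the scatter), so this position tolerates far more than the pyridin-3-yl and cycloheptyl results suggested. The modest a number 13 percentage points lower from compound 1 to compound 4 (beyond the scatter) shows that the low numbers do not depend on chlorine or on the 2,4-dichlorophenyl arrangement, and 3,4-difluorophenyl gives the lowest number of the four compounds. Across these four compounds, both halogenated phenyl groups give low numbers and both groups without halogen give high numbers, but nothing here explains that split.

Unsubstituted phenyl would show whether the halogens are needed at all, and 4-fluorophenyl or 3-fluorophenyl would show whether one fluorine suffices. A methoxy group or a nitrile on the phenyl ring would test whether this trend extends beyond halogens.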